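Acyl ring size on the amide of the shared core

The compounds below may be only part of what the source reports. "The series", "measured", "known", "first", "only" and "open" are said of these compounds alone.

Measured so far in an assay on CHO-K1 cells for displacement of a labelled ligand from prostaglandin E2 receptor EP1 subtype (Homo sapiens); a higher number here means a weaker inhibitor, a lower number a stronger inhibitor:
compound 1 `Cc1cc(C(=O)NCc2cccnc2)nn1Cc1cc(Cl)ccc1OCc1ccccc1`: 50.1 nM
compound 2 `Cc1cc(NC(=O)C2CCCO2)nn1Cc1cc(Cl)ccc1OCc1ccccc1`: 39.8 nM

Among the compounds with values here, compound 2 sits at the same level as compound 1 within the scatter; the single measured step, a 1.3-fold lower number from compound 1 to compound 2 (0.10 log units; within the scatter), is itself within the scatter. Compound 3 `Cc1cc(NC(=O)C2CCOCC2)nn1Cc1cc(Cl)ccc1OCc1ccccc1` is not yet measured in this assay. It differs from compound 2 in one place: oxan-4-yl in place of oxolan-2-yl on a carbonyl carbon. Within the data shown here, no measured step touches the ring of the acyl group, so the only guide is that the one step seen stayed within the scatter. Compound 3 is therefore expected near compound 2, with no step beyond the scatter in either direction. Compound 3 is estimated at 40 nM, within 15 nM to 110 nM. The expected step is a 1.0-fold higher number from compound 2 to compound 3 (0.00 log units; within the scatter).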

Compound 3, half-maximal inhibitory concentration: 63.1 nM
The estimate for compound 3 lay 1.6-fold (0.20 log units) below the measured number, and the stated range covers the measured number.
By their numbers in this assay, from the lowest: compounds 2, 1 and 3 (each within the scatter of the next).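

In this assay, the change in the acyl ring, oxan-4-yl in place of oxolan-2-yl on a carbonyl carbon, gives a 1.6-fold higher number from compound 2 to compound 3 (0.20 log units; within the scatter) and so stays within the scatter for the six-membered and five-membered rings. The replacement of ((pyridin-3-yl)methyl)carbamoyl by ((oxan-4-yl)carbonyl)amino gives a 1.3-fold higher number from compound 1 to compound 3 (0.10 log units; within the scatter) and also stays within the scatter. No measurement at hand explains these values.

Still open, as far as these compounds go, is whether an amine or a carboxylic acid on the acyl ring would take the number beyond the scatter. The same question stands for a longer chain in place of the ring.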